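Swapping selenium for sulfur on a fused core

A few compounds are considered here, and "the series" means these few. Any claim that something is new, unique, unknown or untested is made for them only; others in the source may bear on it.

Compound 1, `CSc1cnc2ccccc2c1SCC#CCCl`: in a functional assay on P388 cells (Mus musculus) for antiproliferative activity, with a stated time of 72 h (a higher number here means a weaker inhibitor, a lower number a stronger inhibitor), compound 1 gives 2.7 ug/mL.
Compound 2, `C#CCSc1cnc2ccccc2c1[Se]CC#CCCl`: in this assay compound 2 gives 0.8 ug/mL.

Among the compounds with values here, only two compounds have been measured so far, and compound 2 holds the lower of the two numbers, which here means the stronger inhibitor; the gap between compound 2 and compound 1 lies beyond the usual scatter of repeated measurements. Within the data shown here, the two compounds differ in more than one place, so no single step between them can be read off.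

Compound 3, `C#CCSc1cnc2ccccc2c1SCC#CCCl`, is the next compound to be measured. It keeps the propargylsulfanyl group of compound 2 and changes only one thing:

a group of 6 heavy atoms (4 carbon, 1 sulfur, 1 chlorine; no ring) in place of a group of 6 heavy atoms (4 carbon, 1 chlorine, 1 selenium; no ring), on an aromatic carbon

Among the measured compounds shown here, no measured pair shows this exact change on its own, so its size cannot be taken from the data. For the measured compounds named here, the only guide is that compound 2, which carries the selenium-containing group, sits at the lower number. On that basis compound 3 is expected to show a modest rise in number, with a 1.9-fold higher number from compound 2 to compound 3 (0.27 log units; within the scatter) as the expected step. Compound 3 is thus estimated at 1.5 ug/mL, within a range of 0.6 ug/mL to 4 ug/mL.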

Compound 3, concentration for 50% inhibition: 3 ug/mL
Beside the measured number, compound 3's estimate is 2.0-fold (0.30 log units) below it; low and high end bracket the measured number.
By their numbers in this assay, from the lowest: compound 2; then compounds 1 and 3 (each within the scatter of the next).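

In this assay, within the data shown here, replacing the selenium of compound 2 with sulfur while leaving the rest of the molecule unchanged gives a 3.8-fold higher number from compound 2 to compound 3 (0.57 log units; beyond the scatter), the first reading of this swap on its own, and it shows that the identity of this single atom, on the aromatic carbon opposite the ring nitrogen, changes the read-out beyond the scatter. The other single change, ethynyl in place of hydrogen on a saturated chain carbon bound to a sulfur, gives a 1.1-fold higher number from compound 1 to compound 3 (0.05 log units; within the scatter), which stays within the scatter, so compound 1 and compound 3 cannot be told apart, and with sulfur at the first position this added ethynyl shows no measurable effect in this assay. Nothing measured here explains why selenium and sulfur differ at this position.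

It remains open whether the selenium-for-sulfur swap would move the number by a similar amount in a compound without the ethynyl, since only one such pair is shown. It is also unknown how an oxygen atom or an amine at the same place would compare, or how a longer chain would behave on the neighbouring propargylsulfanyl position.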